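The source may report more compounds than this note shows. Statements on the series, on what has been measured and on what is new or still open speak of the compounds shown alone.

Working notes on the series. The common core of the series carries a propyl group and a cinnamoyl amide; it is read in a functional assay on HEK293 cells for activation of melanin-concentrating hormone receptor 1 (Homo sapiens), read by inositol phosphate accumulation; a lower number here means that less compound is needed, a higher number that more compound is needed for the effect. Compound 1 `CCCc1ccc(/C=C/C(=O)Nc2ccc3nc(CCC)cc(N)c3c2)cc1` gives 3600 nM in this assay, and compound 2 `CCCCc1ccc(/C=C/C(=O)Nc2ccc3nc(CCC)cc(N)c3c2)cc1` gives 740 nM. For the measured compounds named here, the only step measured in one place, a 4.9-fold lower number from compound 1 to compound 2 (0.69 log units; beyond the scatter), concerns the chain on the distal aromatic ring. Compound 3 `CCCc1cc(N2CCC2)c2cc(NC(=O)/C=C/c3ccc(C(F)(F)F)cc3)ccc2n1` gives 2500 nM in this assay, which stands second highest of the three numbers: it lies within the scatter of compound 1 and is separated from compound 2 by a gap beyond the scatter.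

Compound 4 `CCCc1cc(OC)c2cc(NC(=O)/C=C/c3ccc(C(F)(F)F)cc3)ccc2n1` differs from compound 3 in one place: methoxy in place of azetidin-1-yl on an aromatic carbon. Going by the values given here, none of the measured steps touches this position or this kind of exchange, so nothing in the data bears on its size or direction. Among the compounds with values here, with no step to lean on, the expectation for compound 4 is no change beyond the scatter, that is no change at the digits printed from compound 3 to compound 4 (within the scatter) in this assay. Compound 4 is therefore estimated at 2500 nM, with a wide range from 700 nM to 9000 nM.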

Compound 4, half-maximal effective concentration: 360 nM
Estimate against measurement, compound 4: 6.9-fold (0.84 log units) above, and the stated range ends above it.
By their numbers in this assay, from the lowest: compound 4; then compound 2; then compounds 3 and 1 (each within the scatter of the next).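

At the aromatic carbon opposite the ring nitrogen, the substituent clearly matters: in this assay the exchange of azetidin-1-yl for methoxy gives a 6.9-fold lower number from compound 3 to compound 4 (0.84 log units; beyond the scatter) on an otherwise unchanged structure. For the compounds shown here, this is the first measured step at this position, and it shows that the shared core responds to a change here as well as to the chain on the distal aromatic ring. The exchange removes the four-membered ring, reduces the heavy-atom count and replaces nitrogen with oxygen all at once, and no available measurement explains the step or separates these differences.

Open, going by these compounds, is whether ethoxy, hydroxyl or dimethylamino at this position would follow methoxy or azetidin-1-yl. Also open, on these data alone, is whether the methoxy step would hold with a butyl chain in place of trifluoromethyl on the distal aromatic ring.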